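This account rests on a few compounds, and the source may have more. Where it says the series, first, only, none or still open, it means among the compounds named here.

Measured so far in a functional assay on MCF7 cells (Homo sapiens) for cytotoxicity, read by MTT assay, with a stated time of 24 h, tested at 16 ug/mL; a higher number here means a stronger effect of the compound at the concentration tested, a lower number a weaker effect:
compound 1 `Cn1c(-c2ccc(NC(=O)CCl)cc2)nc(-c2ccccc2)c1-c1ccccc1` — 15.2%
compound 2 `Cn1c(-c2ccc(NC(=O)CSc3nc4cc(Cl)ccc4o3)cc2)nc(-c2ccccc2)c1-c1ccccc1` — 40%
compound 3 `CN1CCN(CC(=O)Nc2ccc(-c3nc(-c4ccccc4)c(-c4ccccc4)n3C)cc2)CC1` — 30.1%

Compound 3 stands second highest of the three: beyond the scatter above compound 1, as a number 14.9 percentage points higher from compound 1 to compound 3 (beyond the scatter) shows, while its gap to compound 2 lies within the scatter, a number 9.9 percentage points lower from compound 2 to compound 3 (within the scatter). Compound 4 `Cn1c(-c2ccc(NC(=O)CN3CCN(Cc4ccccc4)CC3)cc2)nc(-c2ccccc2)c1-c1ccccc1` differs from compound 3 by phenyl in place of hydrogen on a saturated chain carbon bound to an amine nitrogen in a ring. Going by the values given here, no measured step touches this place. The steps of a number 24.8 percentage points higher from compound 1 to compound 2 (beyond the scatter) and a number 14.9 percentage points higher from compound 1 to compound 3 (beyond the scatter) both exchange the group on the saturated chain carbon bound to the carbonyl carbon, which compound 3 and compound 4 carry unchanged. The measured pairs give no direction for the new change, so the expected step is one of no size beyond the scatter, a number 0.1 percentage points lower from compound 3 to compound 4 (within the scatter). Compound 4 is estimated at 30%, between 15% and 45%.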

Compound 4, a percentage reported as activity, at one concentration (the size of the read-out at that concentration, not a potency): 28.3%
Compound 4: the middle estimate sits 1.7 percentage points above what was measured, within the range that was stated.
By their numbers in this assay, from the lowest: compound 1; then compounds 4, 3 and 2 (each within the scatter of the next, the first and the last beyond it).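

Phenyl in place of hydrogen on a saturated chain carbon bound to an amine nitrogen in a ring, which also reads as methyl to benzyl, gives a number 1.8 percentage points lower from compound 3 to compound 4 (within the scatter) in this assay. Going by these compounds alone, this is the first reading at this place, and it shows that a phenyl of 6 heavy atoms can enter here without moving the number beyond the scatter. Nothing available bears on the reason for this result.

Going by these compounds, what an amine or a carboxylic acid on that phenyl would do remains open, as does the effect of a longer chain in place of benzyl.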